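A few compounds are considered here, and "the series" means these few. Any claim that something is new, unique, unknown or untested is made for them only; others in the source may bear on it.

Compound 3 `CCN1CCCC1CNC(=O)c1cc(N(C)S(=O)(=O)N(C)C)ccc1OC` gives the highest number of the three measured in a functional assay on the whole organism for inhibition, with Mus musculus as the target (a lower number here means that less compound is needed, a higher number that more compound is needed for the effect), at 36.2 mg/kg. Compound 1 `CCN1CCCC1CNC(=O)c1cc(N(C)S(C)(=O)=O)c(Cl)cc1OC` gives 7.7 mg/kg and compound 2 `CCN1CCCC1CNC(=O)c1cc(NS(=O)(=O)N(C)C)c(Cl)cc1OC` gives 8.3 mg/kg, and the step of a 1.1-fold higher number from compound 1 to compound 2 (0.03 log units; within the scatter) lies within the scatter, so that exchange matters little here. Compound 4 `CCN1CCCC1CNC(=O)c1cc(N(C)S(=O)(=O)N(C)C)c(Cl)cc1OC` takes (chloro in place of hydrogen on an aromatic carbon). Among the compounds with values here, no measured step covers this change on its own, since compound 2 differs from compound 3 in two places, yet compound 1 and compound 2, which both carry the chloro group, sit far below compound 3. Compound 4 is therefore expected to need a lower dose, a step of a 3.6-fold lower number from compound 3 to compound 4 (0.56 log units; beyond the scatter). The estimate for compound 4 is 10 mg/kg, with a range from 4 mg/kg to 30 mg/kg.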

Compound 4, dose for half-maximal effect: 31.8 mg/kg
The estimate for compound 4 lay 3.2-fold (0.50 log units) below the measured number; measured number above the stated range.
By their numbers in this assay, from the lowest: compounds 1 and 2 (each within the scatter of the next); then compounds 4 and 3 (each within the scatter of the next).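

In this assay chloro in place of hydrogen, ortho to the (dimethylsulfamoyl)(methyl)amino group, changes little on this sulfonamide (a 1.1-fold lower number from compound 3 to compound 4 (0.06 log units; within the scatter)). The chloro group alone therefore does not set compound 1 and compound 2 apart from compound 3. With chloro present, the number rises both with methyl on the sulfonamide nitrogen (a 3.8-fold higher number from compound 2 to compound 4 (0.58 log units; beyond the scatter)) and with dimethylamino on the sulfonyl sulfur (a 4.1-fold higher number from compound 1 to compound 4 (0.62 log units; beyond the scatter)), so compound 4 carries both features without the low number of compound 1 or compound 2.

Nothing here explains this behaviour. From the compounds shown here alone, whether bromo or an amine at this position would behave like chloro stays open.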